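A few compounds are considered here, and "the series" means these few. Any claim that something is new, unique, unknown or untested is made for them only; others in the source may bear on it.

Working notes on the series. Compound 1 `CCN(CC)C(=S)SCc1nc2cc(Cl)c(Cl)cc2[nH]1` carries a diethyl thiocarbamate group on the shared core; compound 2 `CCOc1ccccc1N1CCN(C(=S)SCc2nc3cc(Cl)c(Cl)cc3[nH]2)CC1` carries a piperazine bearing 2-ethoxyphenyl instead. In a functional assay on MCF7 cells (Homo sapiens) for cytotoxicity, read by MTT assay, with a stated time of 24 h (on this read-out lower numbers stand for stronger inhibition and higher numbers for weaker inhibition), compound 1 gives 12600 nM and compound 2 gives 16200 nM; the two numbers lie within the scatter of each other, so neither stands apart. Compound 3 `CN1CCN(C(=S)SCc2nc3cc(Cl)c(Cl)cc3[nH]2)CC1` has not been measured. It differs from compound 2 by methyl in place of 2-ethoxyphenyl on an amine nitrogen in a ring. Going by the values given here, no step between measured compounds exists to guide this change, so no shift beyond the scatter is expected from compound 2 to compound 3 in this assay. Compound 3 is estimated at 15000 nM, range 6000 nM to 40000 nM, a step of a 1.1-fold lower number from compound 2 to compound 3 (0.03 log units; within the scatter).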

Compound 3, half-maximal inhibitory concentration: 30500 nM
Compound 3: middle estimate off by 2.0-fold (0.31 log units), on the low side; the measured number falls inside the stated range.
By their numbers in this assay, from the lowest: compounds 1, 2 and 3 (each within the scatter of the next, the first and the last beyond it).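

In this assay, going by these compounds alone, methyl in place of 2-ethoxyphenyl on the ring amine nitrogen gives a 1.9-fold higher number from compound 2 to compound 3 (0.27 log units; within the scatter) and so stays within the scatter, even with the six-membered aromatic ring gone from this position. 4-Methylpiperazin-1-yl in place of diethylamino on the thiocarbonyl carbon gives a 2.4-fold higher number from compound 1 to compound 3 (0.38 log units; beyond the scatter) and is the only step here beyond the scatter, though a modest one. Nothing on hand gives a reason for either step.

Open, on these data alone, is whether an unsubstituted phenyl, a longer alkyl chain or a carboxylic acid on this ring nitrogen would move the number beyond the scatter. Also open, as far as these compounds go, is whether a morpholine on the thiocarbonyl carbon would read closer to diethylamino or to 4-methylpiperazin-1-yl.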